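Removing the fluoro from the phenyl: working notes

A few compounds are considered here, and "the series" means these few. Any claim that something is new, unique, unknown or untested is made for them only; others in the source may bear on it.

Compound 3 `Cc1ccncc1-c1cccc2c1cnn2-c1ccc(F)cc1` has no number in an ADME assay on liver (Macaca fascicularis) for metabolic stability, using microsomes, with a stated time of 10 min, tested at 0.5 uM; on this read-out higher numbers stand for a more stable compound and lower numbers for a less stable compound; for compound 3 the entry reads "not determined" (no result reported). Compound 1 `Cc1ccncc1-c1cccc2c1cnn2-c1cccnn1` is in the same position: in this assay compound 1 gives "not determined" (no result reported). Among the measured compounds shown here, the only member of the set with a result is compound 2 `Cc1ccncc1-c1cccc2c1ncn2-c1cscn1`, which in this assay gives 50%; its core and its pendant ring both differ from those of compound 3, so no step connects the two and their values can only be set side by side. Compound 3 thus stands without any number to anchor it, and compound 4 `Cc1ccncc1-c1cccc2c1cnn2-c1ccccc1`, not yet tested, can only be judged from the set as a whole.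

Compound 4 differs from compound 3 by hydrogen in place of fluoro on an aromatic carbon. For the measured compounds named here, no measured pair shows what this change does in this assay. The expectation is a step of no more than the usual scatter, in either direction, since the single result in the set comes from compound 2 with its 50% and offers no lever on the fluoro.

For compound 4 the expected fraction remaining in this assay is estimated at 45%, with a range of 15% to 80%. Going by the values given here, the width of that range reflects that the only measured value, from compound 2 at 50%, comes from a different core.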

Compound 4, percent of the compound remaining: 39%
For compound 4 the middle estimate is 6 percentage points above the measured one; the range from low to high includes it.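

In this assay, among the compounds shown here, compound 4 gives 39% while compound 3 reads "not determined" (no result reported) and so no step from 4-fluorophenyl to phenyl can be read between them. The compounds shown leave open what exchanging fluoro for hydrogen does to the fraction remaining. No supporting data bear on this result.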